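The source may hold more compounds than are shown below. What is called first, only, known or untested is meant among the compounds shown, and "the series" means these compounds.

Working notes on the series

Three compounds of this series have been run in a functional assay for inhibition, with Homo sapiens as the target; on this read-out higher numbers stand for weaker inhibition and lower numbers for stronger inhibition. Compound 1 `Cc1cc2c(cc1C(=O)N=C(N)N)S(=O)(=O)CC2(C)O` gives 115 nM. Compound 3 `Cc1cc2c(cc1C(=O)N=C(N)N)S(=O)(=O)CC2C` gives 182 nM. Compound 2 `Cc1cc2c(cc1C(=O)N=C(N)N)S(=O)(=O)C(C)(C)C2(C)O` gives 102 nM. The difference between the cores of compound 1 and compound 2 is not broken down here.

One change recurs. From compound 1 to compound 3 the change is hydrogen in place of hydroxy on a saturated ring carbon, and the step is a 1.6-fold higher number from compound 1 to compound 3 (0.20 log units; within the scatter).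

Compound 4 `Cc1cc2c(cc1C(=O)N=C(N)N)S(=O)(=O)C(C)(C)C2C` has not been measured. Relative to compound 2 the change is hydrogen in place of hydroxy on a saturated ring carbon. This is the same kind of change as that from compound 1 to compound 3, but not the same: in compound 4 the saturated ring carbon is next to the ring atom that bears two methyl groups, which is absent in the earlier pair.

On this basis the step from compound 2 to compound 4 is expected to be a 1.6-fold higher number from compound 2 to compound 4 (0.21 log units; within the scatter) in this assay, resting on the step from compound 1 to compound 3 of a 1.6-fold higher number from compound 1 to compound 3 (0.20 log units; within the scatter) and on compound 2 at 102 nM. Compound 4 is therefore estimated at 165 nM, with a range of 85 nM to 320 nM.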

Compound 4, half-maximal inhibitory concentration: 306 nM
Compound 4: the middle estimate sits 1.9-fold (0.27 log units) below what was measured; low and high end bracket the measured number.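

In this assay, hydrogen in place of hydroxy on the saturated ring carbon gives a 3.0-fold higher number from compound 2 to compound 4 (0.48 log units; beyond the scatter) on the core of compound 2, a step beyond the scatter, while the earlier step on the core of compound 1 lies within it. Set side by side, the two steps cannot be told apart: the same change on two cores in this assay, a 1.6-fold higher number (0.20 log units; within the scatter) from compound 1 to compound 3 and a 3.0-fold higher number (0.48 log units; beyond the scatter) from compound 2 to compound 4, 1.9-fold (0.28 log units) apart, within the scatter of two such steps. Within the limits of these two pairs, the change can therefore be carried from one core to the other without a measurable difference in step size, but this does not show that the step is constant, nor does it tie any part of the gap to the two methyl groups present in compound 2 and compound 4.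

On these data alone, only hydroxy and hydrogen appear at this saturated ring carbon, so it remains open how an amine, a methoxy group or a fluorine atom would read there on either core. Also open, as far as these compounds go, is how the same change would read on any core beyond these two.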